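Replacing the acetoxymethyl of compound 1 with a thioester

The compounds below may be only part of what the source reports. "The series", "measured", "known", "first", "only" and "open" are said of these compounds alone.

Compound 1 `CCCOC(=O)c1[nH]c(COC(C)=O)c(C(=O)OC(C)(C)C)c1C` is the weakest of the three compounds measured in an assay on CHO cells for inhibition of metabotropic glutamate receptor 1 (Rattus norvegicus); a lower number here means a stronger inhibitor, a higher number a weaker inhibitor: compound 1 gives 2700 nM, the highest of the three numbers. Compound 2 `Cc1c(C(=O)OC(C)(C)C)c[nH]c1C(=O)OCC1CC1` gives 48 nM, and compound 3 `CCOC(=O)c1[nH]cc(C(=O)OC(C)(C)C)c1C` gives 340 nM. Within the data shown here, the one step available between single-point changes is a 7.1-fold higher number from compound 2 to compound 3 (0.85 log units; beyond the scatter). Compound 3 differs from compound 1 in two places at once, so its two values show only that the smaller ester together with the bare ring carbon comes out at a lower number.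

Compound 4 `CCCOC(=O)c1[nH]c(C(=O)Sc2ccccn2)c(C(=O)OC(C)(C)C)c1C` carries ((pyridin-2-yl)sulfanyl)carbonyl in place of acetoxymethyl on an aromatic carbon. The new group sits on the ring carbon next to the ring nitrogen and next to the ring atom that bears the tert-butoxycarbonyl group. Among the measured compounds shown here, no measured step touches this position or this kind of group, so the step from compound 2 to compound 3, which concerns the ester chain, does not bear on it directly. With nothing to anchor the direction, the expectation for compound 4 is a number in the same broad region as compound 1, with wide uncertainty, expressed as a 1.8-fold lower number from compound 1 to compound 4 (0.26 log units; within the scatter). Compound 4 is therefore estimated at 1500 nM, within a range of 300 nM to 8000 nM.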

Compound 4, half-maximal inhibitory concentration: 3200 nM
Beside the measured number, compound 4's estimate is 2.1-fold (0.33 log units) below it; low and high end bracket the measured number.
By their numbers in this assay, from the lowest: compound 2; then compound 3; then compounds 1 and 4 (each within the scatter of the next).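

In this assay, the exchange of acetoxymethyl for ((pyridin-2-yl)sulfanyl)carbonyl on this aromatic carbon gives a 1.2-fold higher number from compound 1 to compound 4 (0.07 log units; within the scatter) and so does not separate the two groups. This is the first single change shown at this position, and it shows that a group with a six-membered aromatic ring and a sulfur can replace one with no ring without moving the number beyond the scatter. No measurement shown here accounts for the two groups reading alike.

From the compounds shown here alone, with only these two groups compared at this position, it remains open whether the number responds to the group here at all, since both were measured with the propoxycarbonyl group in place and a bare ring carbon was seen only alongside smaller esters. A hydrogen, a methyl, a carboxylic acid or an amine on this aromatic carbon, with the rest of compound 1 unchanged, would show whether the position can shift the number and in which direction.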